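The source may hold more compounds than are shown below. What is called first, only, known or untested is meant among the compounds shown, and "the series" means these compounds.

Compound 1 `S=c1oc(-c2ccc3c(c2)OCCO3)nn1CN1CCN(c2cccc(Cl)c2Cl)CC1` and compound 2 `COc1ccccc1N1CCN(Cn2nc(-c3ccc4c(c3)OCCO4)oc2=S)CC1` share a core and differ only in the aryl group on the amine nitrogen of the six-membered ring. In a functional assay on BGC-823 cells (Homo sapiens) for antiproliferative activity, read by MTT assay, with a stated time of 48 h (on this read-out higher numbers stand for weaker inhibition and lower numbers for stronger inhibition), compound 1 gives 22600 nM, and in this assay compound 2 gives 19500 nM. The step of a 1.2-fold lower number from compound 1 to compound 2 (0.06 log units; within the scatter) therefore leaves the two values within the scatter of each other, so neither stands apart. Compound 3 `O=[N+]([O-])c1ccc(N2CCN(Cn3nc(-c4ccc5c(c4)OCCO5)oc3=S)CC2)cc1` is obtained from compound 2 by the change (4-nitrophenyl in place of 2-methoxyphenyl on an amine nitrogen in a ring). Among the compounds with values here, the only measured step that bears on this change is the aryl swap on the same ring nitrogen, and that step was small. On this basis the step in this assay from compound 2 to compound 3 is expected to be a 1.0-fold higher number from compound 2 to compound 3 (0.01 log units; within the scatter), that is none beyond the scatter. For compound 3 the value in this assay is estimated at 20000 nM, with a range from 8000 nM to 50000 nM.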

Compound 3, half-maximal inhibitory concentration: > 50000 nM
Compound 3: only a limit was reported; the forecaster's own chance of this, stated with the estimate: 10%; middle value at least 2.5-fold (0.39 log units) away from the limit.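

In this assay compound 3 gives > 50000 nM, which is a limit of the assay and not a number. Within the data shown here, the group on this amine nitrogen in a ring is therefore not indifferent, as the one earlier swap might have suggested: 4-nitrophenyl gives an at least 2.5-fold higher number from compound 2 to compound 3 (0.40 log units; beyond the scatter) and an at least 2.2-fold higher number from compound 1 to compound 3 (0.34 log units; beyond the scatter), both weaker than the two earlier aryl groups. These steps are only lower bounds, and how far compound 3 lies beyond them cannot be read: the limit of > 50000 nM in this assay, at which 1 of the 3 values shown sits.

The compounds shown leave open whether the step follows the nitro group itself or where it stands on the phenyl ring, since 4-nitrophenyl differs from the other two aryl groups in both. A 2-nitrophenyl, a 4-methoxyphenyl or an unsubstituted phenyl on the same nitrogen would bear on that question.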